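The compounds below may be only part of what the source reports. "The series", "measured", "known", "first", "only" and "open" are said of these compounds alone.

Compound 1, `COC(=O)c1ccc(CN(CCCc2c(N)nc(N)nc2O)c2cc(F)cc(F)c2[N+](=O)[O-])cc1`, shows little activity in a functional assay on CCRF-CEM cells (Homo sapiens) for cytotoxicity, in the absence of a further agent; a higher number here means a weaker inhibitor, a lower number a stronger inhibitor: its value there, > 100000 nM, is only a limit of the assay and not a number. Compound 2, `Nc1nc(N)c(CCCNc2cc(F)cc(F)c2[N+](=O)[O-])c(O)n1`, in this assay gives 97000 nM. The step of an at least 1.0-fold lower number from compound 1 to compound 2 (0.01 log units; that floor lies within the scatter) takes away a whole benzyl group and still stays within the scatter. Compound 3, `Nc1nc(N)c(CCCN(Cc2ccc(NC(CCC(=O)O)C(=O)O)cc2)c2cc(F)cc(F)c2[N+](=O)[O-])c(O)n1`, differs from compound 1 by (1,3-dicarboxypropyl)amino in place of methoxycarbonyl on an aromatic carbon. Within the data shown here, no measured step touches this particular change. Among the measured compounds shown here, the only step at hand, from compound 1 to compound 2, is broader in scope and moved nothing beyond the scatter. Compound 1 itself sits at the limit of the assay (the limit of > 100000 nM in this assay, at which 1 of the 2 values shown sits). The expected step of a number no higher from compound 1 to compound 3 (the limit leaves the size open) is therefore estimated to lie within the scatter, with no direction to it. Compound 3 is estimated to give 100000 nM in this assay, with a range from 30000 nM to 300000 nM.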

Compound 3, half-maximal inhibitory concentration: > 100000 nM
Compound 3 gave a limit, no number (the forecaster's own chance of this, stated with the estimate: 60%); the middle value sits exactly at the limit.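

Compound 3, like compound 1, gives only a limit and not a number in this assay, so no step between the two can be read: the limit of > 100000 nM in this assay, at which 2 of the 3 values shown sit.

The compounds shown leave open whether (1,3-dicarboxypropyl)amino in place of methoxycarbonyl changes the cytotoxicity read-out at all.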